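The source may hold more compounds than are shown below. What is called first, only, known or untested is meant among the compounds shown, and "the series" means these compounds.

The measured compounds, with their values in a physicochemical assay for lipophilicity; on this read-out lower numbers stand for lower lipophilicity and higher numbers for higher lipophilicity:

Compound 1, `Cc1ccccc1C1=NO[C@]2(C1)C(=O)O[C@@H]1[C@H]2CC[C@H](C)[C@]2(O)C=CC(=O)[C@@]12C`, gives 1.86.
Compound 2, `C[C@H]1CC[C@@H]2[C@@H](OC(=O)[C@]23CC(c2ccc(F)cc2)=NO3)[C@]2(C)C(=O)C=C[C@@]12O`, gives 1.58.
Compound 3, `C[C@H]1CC[C@@H]2[C@@H](OC(=O)[C@]23CC(c2ccc(F)cc2)N(c2ccccc2)O3)[C@]2(C)C(=O)C=C[C@@]12O`, gives 3.35.

Compound 3 stands highest of the three in this assay; its nearest neighbour is compound 1, a number lower than it beyond the scatter, and compound 2 lies further below it again, also beyond the scatter. Among the compounds with values here, the only step measured between compounds differing in one place is the one from compound 1 to compound 2, which brings 4-fluorophenyl in place of 2-methylphenyl on a carbon with a double bond to nitrogen: a number 0.28 log units lower from compound 1 to compound 2 (within the scatter).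

Compound 4 is `C[C@H]1CC[C@@H]2[C@@H](OC(=O)[C@]23CC(c2ccccc2F)N(c2ccccc2)O3)[C@]2(C)C(=O)C=C[C@@]12O`. It differs from compound 3 only in the arrangement of the same atoms: 2-fluorophenyl in place of 4-fluorophenyl on a saturated ring carbon. Within the data shown here, no measured step moves a fluorine around an aromatic ring in this way, so the step from compound 1 to compound 2 bears on it only loosely, and that step stayed within the scatter. The expected step in this assay from compound 3 to compound 4 is therefore small, a number 0.05 log units lower from compound 3 to compound 4 (within the scatter), with no clear direction beyond the scatter. Compound 4 is estimated at 3.3, within a range from 2.9 to 3.7.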

Compound 4, partition coefficient: 3.35
Compound 4: middle estimate off by 0.05 log units, on the low side; the measured number falls inside the stated range.
By their numbers in this assay, from the lowest: compounds 2 and 1 (each within the scatter of the next); then compounds 3 and 4 (each within the scatter of the next).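

In this assay the reading gives no change at the digits printed from compound 3 to compound 4 (within the scatter) when 2-fluorophenyl stands in place of 4-fluorophenyl on a saturated ring carbon. Within the data shown here, this is the first measured step in which only the place of the fluorine on the aromatic ring changes, with the rest of the compound held fixed. The earlier step exchanged a methyl-bearing ring for a fluorine-bearing one on a carbon with a double bond to nitrogen, so it could not isolate this move, and here the two fluorine placements cannot be told apart on this read-out, though nothing on hand explains why.

The compounds shown leave open whether 3-fluorophenyl, or a ring carrying a chlorine, a nitrile or a methoxy group, would read the same at this saturated ring carbon, and whether a carboxylic acid or an amine on that ring would move the number beyond the scatter. They also leave open whether the same fluorine move would read alike on the carbon with a double bond to nitrogen, where the ring nitrogen carries no phenyl group.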